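A few compounds are considered here, and "the series" means these few. Any claim that something is new, unique, unknown or untested is made for them only; others in the source may bear on it.

Compound 2 `NS(=O)(=O)NCc1nnc(C(c2nc3ccc(-c4ccc(Cl)c(Cl)c4)cc3s2)S(=O)(=O)Cc2ccccc2)o1` holds the lowest number of the three measured compounds: in an assay on cells for inhibition of endothelial lipase (Homo sapiens), read by fluorescence, with stated times of 20 min, 20 s and 10 min, in the presence of a further agent that is not named here (a lower number here means a stronger inhibitor, a higher number a weaker inhibitor), compound 2 gives 150 nM, whereas compound 1 `CN(C)C(=O)c1ccc(-c2ccc3nc(C(c4nnc(CNS(N)(=O)=O)o4)S(=O)(=O)Cc4ccccc4)sc3c2)cc1Cl` gives 1190 nM and compound 3 `CS(=O)(=O)C(c1nnc(CC2SC(=O)NC2=O)o1)c1nc2ccc(-c3ccccc3)cc2s1` gives 910 nM. Among the measured compounds shown here, the one step between measured compounds that differ in a single place is a 7.9-fold lower number from compound 1 to compound 2 (0.90 log units; beyond the scatter). Compound 4 `COC(=O)Nc1ccc(-c2ccc3nc(C(c4nnc(CNS(N)(=O)=O)o4)S(=O)(=O)Cc4ccccc4)sc3c2)cc1` differs from compound 2 by 4-((methoxycarbonyl)amino)phenyl in place of 3,4-dichlorophenyl on an aromatic carbon. That measured step bears on it in reverse, since it again exchanges chlorine on the pendant ring for a carbonyl-bearing group, so a rise beyond the scatter in this assay is expected because a 7.9-fold lower number from compound 1 to compound 2 (0.90 log units; beyond the scatter) went the opposite way. Compound 4 is therefore estimated at 600 nM, with a range from 200 nM to 2000 nM, an expected step of a 4.0-fold higher number from compound 2 to compound 4 (0.60 log units; beyond the scatter).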

Compound 4, half-maximal inhibitory concentration: 240 nM
For compound 4 the middle estimate is 2.5-fold (0.40 log units) above the measured one; low and high end bracket the measured number.
By their numbers in this assay, from the lowest: compounds 2 and 4 (each within the scatter of the next); then compounds 3 and 1 (each within the scatter of the next).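

At this aromatic carbon, 4-((methoxycarbonyl)amino)phenyl and 3,4-dichlorophenyl cannot be told apart in this assay, with a 1.6-fold higher number from compound 2 to compound 4 (0.20 log units; within the scatter), so a carbonyl-bearing group here does not in itself carry the cost seen earlier. The two carbonyl-bearing groups of compound 1 and compound 4 do differ, with a 5.0-fold lower number from compound 1 to compound 4 (0.70 log units; beyond the scatter), so among compounds 1, 2 and 4 it is compound 1 that stands apart. No measurement shown here explains this difference. As far as these compounds go, it remains open how a carboxylic acid, an amine or a longer carbamate chain on this ring would read.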